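Swapping Trifluoromethyl for Methyl on the Benzyl Ring

This account rests on a few compounds, and the source may have more. Where it says the series, first, only, none or still open, it means among the compounds named here.

Compound 1 `O=C(NC1CCN(Cc2ccc(C(F)(F)F)cc2)CC1)c1cccc2ccccc12` gives 96 nM in an assay on isolated protein for displacement of a labelled ligand from D(4) dopamine receptor (Homo sapiens); on this read-out lower numbers stand for stronger inhibition and higher numbers for weaker inhibition.
Compound 2 `O=C(NC1CCN(Cc2cccc(Cl)c2)CC1)c1ccc2ccccc2c1` gives 54 nM in this assay.
Compound 3 `O=C(NC1CCN(Cc2ccc(C(F)(F)F)cc2)CC1)c1ccc2ccccc2c1` gives 84 nM in this assay.

Compound 3 stands second of the three numbers, but both neighbours are close: the step of a 1.1-fold lower number from compound 1 to compound 3 (0.06 log units; within the scatter) and the step of a 1.6-fold higher number from compound 2 to compound 3 (0.19 log units; within the scatter) each lie within the scatter, so nothing separates these three compounds with confidence.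

Compound 4 `Cc1ccc(CN2CCC(NC(=O)c3ccc4ccccc4c3)CC2)cc1` differs from compound 3 by methyl in place of trifluoromethyl on an aromatic carbon. The measured step that bears on this is a 1.6-fold higher number from compound 2 to compound 3 (0.19 log units; within the scatter), which changed the group on the same benzyl ring and stayed within the scatter; the step of a 1.1-fold lower number from compound 1 to compound 3 (0.06 log units; within the scatter) concerns the other end of the molecule. Among the measured compounds shown here, no measured step exchanges trifluoromethyl for methyl directly. The expected step is therefore a 1.1-fold lower number from compound 3 to compound 4 (0.05 log units; within the scatter), nothing beyond the scatter. Compound 4 is estimated at 75 nM, with a likely range from 30 nM to 200 nM.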

Compound 4, inhibition constant: 21 nM
Estimate against measurement, compound 4: 3.6-fold (0.55 log units) above, and the stated range ends above it.
By their numbers in this assay, from the lowest: compound 4; then compounds 2, 3 and 1 (each within the scatter of the next).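

At the aromatic carbon para to a large group, the choice of group clearly matters in this assay (a 4.0-fold lower number from compound 3 to compound 4 (0.60 log units; beyond the scatter)), whereas the earlier change on this benzyl ring stayed within the scatter. The 4-methylphenyl group also beats 3-chlorophenyl (a 2.6-fold lower number from compound 2 to compound 4 (0.41 log units; beyond the scatter)), so a change on this ring can move the number measurably. Nothing measured here explains why methyl outperforms trifluoromethyl. As far as these compounds go, whether ethyl, methoxy or plain hydrogen at this place would do better remains open. So does whether methyl brings the same gain with naphthalen-1-yl on the carbonyl carbon.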